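Aryl swap on the amine of a diarylurea series

A few compounds are considered here, and "the series" means these few. Any claim that something is new, unique, unknown or untested is made for them only; others in the source may bear on it.

Compound 2 `CCc1ccc(Nc2cc(NC(=O)Nc3c(Cl)cccc3Cl)ncn2)cc1`: 38.1%
Compound 3 `COc1cc(NC(=O)Nc2cc(Nc3cc(C)cc(F)c3)ncn2)cc(OC)c1`: 28.3%
Compound 1 `COc1cc(NC(=O)Nc2cc(Nc3ccc(OC)c(C)c3)ncn2)cc(OC)c1`: 19.7%

In a functional assay on NCI-H1581 cells (Homo sapiens) for inhibition, read by MTT assay, with a stated time of 48 h, tested at 10 uM (on this read-out higher numbers stand for more inhibition at the one concentration tested (going by the name of the read-out) and lower numbers for less inhibition), compound 2 gives the highest of the three numbers, but its gap to compound 3 lies within the scatter, and only compound 1 sits beyond it. Compound 4 `Cc1ccc(Nc2cc(NC(=O)Nc3c(Cl)cccc3Cl)ncn2)cc1C` is not yet measured; it differs from compound 2 by 3,4-dimethylphenyl in place of 4-ethylphenyl on a nitrogen on an aromatic ring. For the measured compounds named here, the one measured step that bears on this place is a number 8.6 percentage points higher from compound 1 to compound 3 (within the scatter), which exchanged one aryl group for another on the same nitrogen and stayed within the scatter. On that basis the step of a number 2.1 percentage points lower from compound 2 to compound 4 (within the scatter) is expected to be small, with no direction beyond the scatter. Compound 4 is therefore estimated at 36%, within a range of 18% to 54%.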

Compound 4, a percentage reported as inhibition, at one concentration (the size of the read-out at that concentration, not a potency): 73.3%
Beside the measured number, compound 4's estimate is 37.3 percentage points below it; the measured number lies above the stated range.
By their numbers in this assay, from the lowest: compounds 1, 3 and 2 (each within the scatter of the next, the first and the last beyond it); then compound 4.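

Even a change that keeps the same atoms can matter at this place on a nitrogen on an aromatic ring: in this assay, 3,4-dimethylphenyl in place of 4-ethylphenyl gives a number 35.2 percentage points higher from compound 2 to compound 4 (beyond the scatter). For the compounds shown here, the one earlier aryl exchange, with a different group on the other side of the urea, gave only a number 8.6 percentage points higher from compound 1 to compound 3 (within the scatter). Nothing shown here explains the size of the new step.

From the compounds shown here alone, it remains open whether a 3-methylphenyl or a 4-methylphenyl group alone would hold this level. Also open, going by these compounds, are a longer chain such as propyl or an amine on that ring, and whether the 3,4-dimethylphenyl gain carries over to the urea partner of compound 1.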